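Bromo Substituent on Two Related Cores and Microsomal Half-life

This account rests on a few compounds, and the source may have more. Where it says the series, first, only, none or still open, it means among the compounds named here.

Measured in an ADME assay on microsomes from liver (Homo sapiens) for metabolic stability; on this read-out higher numbers stand for a longer-lived compound and lower numbers for a shorter-lived compound:
compound 1, `CCCNC(=O)C1CCN(C(=O)c2cc3ccsc3n2Cc2ccc(OC)cc2)CC1`, gives 0.068 h
compound 2, `CCCNC(=O)C1CCN(C(=O)c2cc3occc3n2Cc2ccc(OC)cc2)CC1`, gives 0.0457 h
compound 3, `CCCNC(=O)C1CCN(C(=O)c2cc3cc(Br)sc3n2Cc2ccc(OC)cc2)CC1`, gives 0.127 h

Compounds 1 and 3 share one core; compound 2 carries another, and the difference between the two cores is not broken down here. Compound 3 differs from compound 1 by bromo in place of hydrogen on an aromatic carbon, and that change gave a 1.9-fold higher number from compound 1 to compound 3 (0.27 log units; within the scatter). Compound 2 and compound 1 lie within the scatter of each other, while compound 3 stands beyond the scatter from compound 2.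

Compound 4, `CCCNC(=O)C1CCN(C(=O)c2cc3oc(Br)cc3n2Cc2ccc(OC)cc2)CC1`, has not yet been measured in this assay. It differs from compound 2 by bromo in place of hydrogen on an aromatic carbon. This is the same kind of change as that from compound 1 to compound 3, made twice among these compounds, but not the same change: in compound 3 the five-membered ring holds a sulfur and the bromo sits next to the ring sulfur, whereas in compound 4 the ring holds an oxygen and the bromo sits next to the ring oxygen.

The step is expected to be a 1.8-fold higher number from compound 2 to compound 4 (0.24 log units; within the scatter) because the same kind of change gave a 1.9-fold higher number from compound 1 to compound 3 (0.27 log units; within the scatter). Compound 4 is therefore estimated at 0.08 h, between 0.04 h and 0.16 h.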

Compound 4, half-life: 0.158 h
Beside the measured number, compound 4's estimate is 2.0-fold (0.30 log units) below it, and the stated range covers the measured number.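

In this assay, bromo in place of hydrogen on an aromatic carbon, next to the ring oxygen, gave a 3.5-fold higher number from compound 2 to compound 4 (0.54 log units; beyond the scatter) on the core of compound 2. Set beside the earlier step on the core of compound 1, this step lies beyond the scatter while the earlier one lies within it, yet the two steps cannot be told apart: the same change on two cores in this assay, a 1.9-fold higher number (0.27 log units; within the scatter) from compound 1 to compound 3 and a 3.5-fold higher number (0.54 log units; beyond the scatter) from compound 2 to compound 4, 1.9-fold (0.27 log units) apart, within the scatter of two such steps. The data therefore do not show that the change behaves differently on the two cores, but with a single pair on each core they do not show that it carries over with the same size either, and they do not explain why the half-life differs within either pair.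

The compounds shown leave open whether a smaller halogen such as chloro, or a methyl group, at the same place would match bromo. They also leave open whether the step would hold with a longer chain in place of the propyl group on the amide.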